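This account rests on a few compounds, and the source may have more. Where it says the series, first, only, none or still open, it means among the compounds named here.

Among the compounds with values here, in a functional assay on the whole organism for inhibition, with Mus musculus as the target, at a dose of 25 mg/kg by the oral route (a lower number here means less inhibition, a higher number more inhibition at the dose given (going by the name of the read-out)), compound 1 `Clc1cccc(N2CCN(CCCCOc3ccc4c(c3)CCC4)CC2)c1` gives 0%, the lowest of the two numbers known here. Within the data shown here, compound 2 `COc1ccc(N2CCN(CCCOc3ccc4c(c3)CCC4)CC2)cc1` gives 37% in this assay, a number beyond the usual scatter higher than that of compound 1, though the two differ in more than one place and no single step links them. Compound 3 `O=[N+]([O-])c1ccc(N2CCN(CCCCOc3ccc4c(c3)CCC4)CC2)cc1` has not been measured; it differs from compound 1 by 4-nitrophenyl in place of 3-chlorophenyl on an amine nitrogen in a ring. Because compound 1 already sits at 0%, the change can hardly lower the number, and a modest rise is expected, a number 20 percentage points higher from compound 1 to compound 3 (beyond the scatter), perhaps no larger than the scatter. Compound 3 is thus expected to give 20% in this assay, within a range from 0% to 55%.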

Compound 3, a percentage reported as inhibition, in the whole organism at one dose (the size of the read-out at that dose, not a potency): 22%
For compound 3 the middle estimate is 2 percentage points below the measured one, and the stated range covers the measured number.
By their numbers in this assay, from the lowest: compound 1; then compound 3; then compound 2.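

In this assay, the group on an amine nitrogen in a ring can move the read-out: 4-nitrophenyl in place of 3-chlorophenyl gives a number 22 percentage points higher from compound 1 to compound 3 (beyond the scatter), with the rest of the structure unchanged. Within the data shown here, the result therefore shows that this position responds to a change of aryl group, which the earlier compounds, differing in more than one place, could not show. No available measurement bears on why this step occurs. Among these compounds, the single step swaps the substituent and its ring location together, leaving their separate contributions unresolved. From the compounds shown here alone, whether a plain phenyl or a nitrile-bearing phenyl would give a similar read-out also remains open.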